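Replacing nitro with amino in compound 3

The source may hold more compounds than are shown below. What is called first, only, known or untested is meant among the compounds shown, and "the series" means these compounds.

Compound 1 `COc1ccc(NS(=O)(=O)/C=C/c2ccccc2OC)cc1`: 5000 nM
Compound 2 `COc1ccc(NS(=O)(=O)/C=C/c2cc(OC)c(OC)c(OC)c2)cc1`: 35000 nM
Compound 3 `COc1ccc(NS(=O)(=O)/C=C/c2cc(OC)c(OC)c(OC)c2)cc1[N+](=O)[O-]`: 75000 nM

These values come from a functional assay on K562 cells (Homo sapiens) for cytotoxicity, read by trypan blue exclusion, with a stated time of 96 h (a higher number here means a weaker inhibitor, a lower number a stronger inhibitor), and compound 3 has the highest number of the three, which makes it the weakest so far. The next structure is compound 4 `COc1ccc(NS(=O)(=O)/C=C/c2cc(OC)c(OC)c(OC)c2)cc1N`, which carries amino in place of nitro on an aromatic carbon, ortho to a methoxy group (amino in place of nitro on an aromatic carbon).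

Among the measured compounds shown here, no measured compound carries amino, so the evidence is indirect. For the measured compounds named here, the one step that bears on this change is a 2.1-fold higher number from compound 2 to compound 3 (0.33 log units; beyond the scatter), a modest step that came with nitro replacing hydrogen at this same place. With the nitro gone, the number in this assay is expected to move back toward compound 2 at 35000 nM, and perhaps a little past it. The expected change is a 3.8-fold lower number from compound 3 to compound 4 (0.57 log units; beyond the scatter), a step toward stronger inhibition, though the estimate is uncertain. For compound 4 the estimated value is 20000 nM, with an expected range from 6000 nM to 70000 nM.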

Compound 4, half-maximal inhibitory concentration: 15000 nM
Compound 4: the middle estimate sits 1.3-fold (0.12 log units) above what was measured, and the stated range covers the measured number.
By their numbers in this assay, from the lowest: compound 1; then compound 4; then compound 2; then compound 3.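

In this assay this place, on an aromatic carbon ortho to a methoxy group, responds in both directions: amino in place of hydrogen gives a lower number (a 2.3-fold lower number from compound 2 to compound 4 (0.37 log units; beyond the scatter)), whereas nitro in place of hydrogen gave a higher one. The change from nitro to amino therefore does more than undo the effect of nitro, and it produces a larger step (a 5.0-fold lower number from compound 3 to compound 4 (0.70 log units; beyond the scatter)) that ends on the stronger side of the hydrogen compound. Nothing available explains why these two groups differ.

From the compounds shown here alone, it remains open how a hydroxyl group or a methylamino group on this same carbon would compare with amino. Also open, going by these compounds, is whether amino would lower the number in the same way on the core of compound 1.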